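A few compounds are considered here, and "the series" means these few. Any claim that something is new, unique, unknown or untested is made for them only; others in the source may bear on it.

Series notes. Compound 1 `O=C(O)c1ccc(N2C(=O)C=CC2=O)cc1`, compound 3 `O=C(O)c1cccc(-n2cccc2)c1` and compound 2 `COC(=O)c1ccc(-c2noc(CCl)n2)cc1` have been run in an ADME assay on MT2 cells (Homo sapiens) for cytotoxicity, read by XTT assay, with a stated time of 4 days; on this read-out higher numbers stand for lower toxicity in this test and lower numbers for higher toxicity in this test. Compound 1 returns no number, only the limit of the test, > 400000 nM; the same reading is the limit of > 400000 nM in this assay, at which 1 of the 3 values shown sits. Compound 3 gives 302000 nM. Compound 2 gives 14200 nM, the lower of the two numbers, with compound 3 as its nearest neighbour at a gap beyond the scatter. Compound 4 `COC(=O)c1ccc(-c2noc(CSC#N)n2)cc1` is the next to be measured; it differs from compound 2 by cyanosulfanyl in place of chloro on a saturated chain carbon bound to an aromatic carbon. Among the compounds with values here, no measured step of this kind exists in the set, so a modest move toward a higher number is expected, not far beyond the scatter. Compound 4 is estimated at 25000 nM, between 8000 nM and 80000 nM. The expected step is a 1.8-fold higher number from compound 2 to compound 4 (0.25 log units; within the scatter).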

Compound 4, half-maximal cytotoxic concentration: 43700 nM
Estimate against measurement, compound 4: 1.7-fold (0.24 log units) below; measured number inside the range.
By their numbers in this assay, from the lowest: compound 2; then compound 4; then compound 3. At a limit, above all of these: compound 1.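

In this assay, within the data shown here, cyanosulfanyl in place of chloro on a saturated chain carbon bound to an aromatic carbon gives a 3.1-fold higher number from compound 2 to compound 4 (0.49 log units; beyond the scatter), the first one-place step, so the read-out responds to the group held at this position. Without chloro, compound 4 still returns a number, 43700 nM, and not a limit. Nothing measured here bears on why the number moves.

Open, on these data alone, is whether an amine, a hydroxyl or a longer chain at this position would move the number further. Also open, as far as these compounds go, is whether the step holds on a core other than that of compound 2.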